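This account rests on a few compounds, and the source may have more. Where it says the series, first, only, none or still open, it means among the compounds named here.

The study concerns a shared core carried by compound 1 `COc1cc(OC)c(/C=C/S(=O)(=O)Cc2cc(N)ccc2OC)c(OC)c1`, compound 2 `COc1cc(OC)c(/C=C/S(=O)(=O)Cc2ccc(Br)c([N+](=O)[O-])c2)c(OC)c1` and compound 3 `COC(=O)CCNc1cc(CS(=O)(=O)/C=C/c2c(OC)cc(OC)cc2OC)ccc1OC`. In a functional assay on DU-145 cells (Homo sapiens) for cytotoxicity, read by trypan blue exclusion, with a stated time of 96 h (on this read-out higher numbers stand for weaker inhibition and lower numbers for stronger inhibition), compound 1 gives 7500 nM, compound 2 gives 25000 nM and compound 3 gives 1500 nM, the lowest of the three numbers, with its gaps to compound 1 and to compound 2 both lying beyond the scatter. Compound 4 `COc1cc(OC)c(/C=C/S(=O)(=O)Cc2ccc(OC)c(NC(C)(C)C(=O)O)c2)c(OC)c1` has not yet been tested. It differs from compound 3 in one place (1-carboxy-1-methylethyl in place of 2-(methoxycarbonyl)ethyl on a nitrogen on an aromatic ring). Among the compounds with values here, no measured pair shows this change, so nothing in the data tells its effect. The expected step is a 2.0-fold higher number from compound 3 to compound 4 (0.30 log units; within the scatter), which is estimated to be small and, if anything, toward weaker inhibition. The estimate for compound 4 in this assay is 3000 nM, within a range of 800 nM to 12000 nM.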

Compound 4, half-maximal inhibitory concentration: 150 nM
Estimate against measurement, compound 4: 20-fold (1.30 log units) above; the whole stated range lies above it.
By their numbers in this assay, from the lowest: compound 4; then compound 3; then compound 1; then compound 2.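

On a nitrogen on an aromatic ring, this assay proves sensitive to the substituent: 1-carboxy-1-methylethyl in place of 2-(methoxycarbonyl)ethyl gives a 10-fold lower number from compound 3 to compound 4 (1.00 log units; beyond the scatter) and makes compound 4 the lowest of the four numbers, although the two groups hold the same atoms. The earlier compounds shown here offered no step at this position. Nothing at hand accounts for this change. The effect of the carboxylic acid cannot be separated from that of the two methyl groups. A straight-chain carboxylic acid or the methyl ester of 1-carboxy-1-methylethyl on this nitrogen would remain to be compared.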